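Swapping the Pyrazinyl Ring for Pyridazinyl in Compound 2

The source may hold more compounds than are shown below. What is called first, only, known or untested is meant among the compounds shown, and "the series" means these compounds.

Compound 2 `CC(C)(C)OC(=O)N1CCC(O[C@H]2CC[C@H](Oc3cnc(S(C)(=O)=O)cn3)CC2)CC1` was measured in a functional assay on isolated protein for agonist activity at Glucose-dependent insulinotropic receptor (Homo sapiens), read by HTRF and cAMP accumulation (a lower number here means a smaller maximal response, a higher number a larger maximal response), and gave 110%. Among the three compounds measured so far, compound 2 stands second highest. Its nearest neighbour is compound 3 `CC(C)S(=O)(=O)c1cnc(O[C@H]2CC[C@H](OC3CCN(C(=O)OC(C)(C)C)CC3)CC2)cn1`, which in this assay gives 109%; the step of a number 1 percentage points lower from compound 2 to compound 3 (within the scatter) is within the scatter. The furthest is compound 1 `CC(C)(C)OC(=O)N1CCC(O[C@H]2CC[C@H](Oc3ccc(S(C)(=O)=O)cc3)CC2)CC1`, which in this assay gives 115%; the step of a number 5 percentage points lower from compound 1 to compound 2 (within the scatter) is also within the scatter.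

Compound 4 `CC(C)(C)OC(=O)N1CCC(O[C@H]2CC[C@H](Oc3ccc(S(C)(=O)=O)nn3)CC2)CC1` has not yet been measured. It differs from compound 2 in one place:

6-(methylsulfonyl)pyridazin-3-yl in place of 5-(methylsulfonyl)pyrazin-2-yl on an oxygen on a saturated carbon

Going by the values given here, the step most closely related is the one from compound 1 to compound 2, where the aromatic ring on the oxygen on the saturated carbon was exchanged, and that step, a number 5 percentage points lower from compound 1 to compound 2 (within the scatter), stayed within the scatter. The other measured step, a number 1 percentage points lower from compound 2 to compound 3 (within the scatter), was likewise within the scatter. Compound 4 is therefore expected to show no step beyond the scatter, a number 2 percentage points lower from compound 2 to compound 4 (within the scatter). Compound 4 is estimated to give 108% in this assay, with a range from 95% to 120%.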

Compound 4, largest response reached (Emax), in percent of the reference or control that the assay uses: 97%
Compound 4: the middle estimate sits 11 percentage points above what was measured; measured number inside the range.
By their numbers in this assay, from the lowest: compound 4; then compounds 3, 2 and 1 (each within the scatter of the next).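

Going by these compounds alone, exchanging 5-(methylsulfonyl)pyrazin-2-yl for 6-(methylsulfonyl)pyridazin-3-yl on the oxygen keeps the same atoms, joined differently, yet in this assay it gives a number 13 percentage points lower from compound 2 to compound 4 (beyond the scatter), the first step in this set beyond the scatter. The step of a number 18 percentage points lower from compound 1 to compound 4 (beyond the scatter) is also beyond the scatter, whereas a number 5 percentage points lower from compound 1 to compound 2 (within the scatter) stayed within it, so this position does respond to the aromatic ring it carries, and rearranging the atoms of that ring is enough to change the maximal response. Nothing available here accounts for the difference.

Going by these compounds, it remains open whether isopropyl on the sulfonyl sulfur, which stayed within the scatter on the pyrazinyl ring, would do the same on the pyridazinyl ring. Also open, on these data alone, is how a pyridine or pyrimidine ring carrying methylsulfonyl would behave on the same oxygen.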